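Taking the Hydroxy Group Off Compound 3

The source may report more compounds than this note shows. Statements on the series, on what has been measured and on what is new or still open speak of the compounds shown alone.

For the measured compounds named here, the measure used here is a functional assay on HeLa cells (Homo sapiens) for antiproliferative activity, read by MTT assay, with a stated time of 48 h (a lower number here means a stronger inhibitor of growth, a higher number a weaker inhibitor of growth), and three compounds have values so far. Compound 1 (`COc1cc(/C=C2\Cc3c(cc(OC)c(OC)c3OC)C2=O)cc(OC)c1OC`) gives 2370 nM in this assay and compound 2 (`COc1ccc(/C=C2\Cc3c(cc(OC)c(OC)c3OC)C2=O)cc1Br`) gives 356 nM in the same test.

Compound 3 (`COc1ccc(/C=C2\Cc3cc(OC)c(OC)c(OC)c3C2=O)cc1O`) gives > 10000 nM in this assay and this entry is a limit of the assay, not a number. Compound 3 therefore has no exact place on the scale.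

Compound 4 (`COc1ccc(/C=C2\Cc3cc(OC)c(OC)c(OC)c3C2=O)cc1`) has not been measured yet. It differs from compound 3 in one place. The counted change is hydrogen in place of hydroxy on an aromatic carbon in short, hydrogen in place of hydroxy on an aromatic carbon, ortho to a methoxy group.

Going by the values given here, no two measured compounds differ in a single place, and none of them shows what this swap does. With a limit as the starting point, the step cannot be given an exact size. A small step is expected, if any, towards a stronger inhibitor of growth, and compound 4 may well return a limit too. The expected step is an at least 1.2-fold lower number from compound 3 to compound 4 (0.09 log units; that floor lies within the scatter) on this estimate. For compound 4 the estimate is 8000 nM with an expected range from 2500 nM to 20000 nM once it is tested.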

Compound 4, concentration for 50% growth inhibition: > 10000 nM
Compound 4: only a limit was reported; the forecaster's own chance of this, stated with the estimate: 55%; middle value at least 1.2-fold (0.09 log units) away from the limit.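

Compound 4 gives only a limit of the assay, as compound 3 does, so the change from hydroxy to hydrogen has no readable size between compound 3 and compound 4: the limit of > 10000 nM in this assay, at which 2 of the 4 values shown sit.

The compounds shown leave open whether this swap changes growth inhibition at all, and how far either compound lies beyond that limit.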